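This account rests on a few compounds, and the source may have more. Where it says the series, first, only, none or still open, it means among the compounds named here.

Working notes on the series.

Of the compounds shown here, three of a shared core have been measured in an assay on membranes from Chem-1 cells for displacement of a labelled ligand from prostaglandin E2 receptor EP3 subtype (Homo sapiens), read by scintillation counting, with a stated time of 2 h; a lower number here means a stronger inhibitor, a higher number a weaker inhibitor. Compound 1 `CC(C)(/C=C1\OC(=O)NC1=O)c1ccc(-c2ccc3cccc(F)c3c2)[nH]c1=O` gives 38 nM. Compound 2 `CCC(/C=C1\OC(=O)NC1=O)(CC)c1ccc(-c2ccc3cccc(F)c3c2)[nH]c1=O` gives 13 nM. Compound 3 `CCc1cccc2ccc(-c3ccc(C(/C=C4\OC(=O)NC4=O)(CC)CC)c(=O)[nH]3)cc12` gives 17 nM. Compound 3 thus stands second highest of the three numbers: its nearest neighbour is compound 2, from which it is separated only by a 1.3-fold higher number from compound 2 to compound 3 (0.12 log units; within the scatter), a change that swaps ethyl in place of fluoro on an aromatic carbon and stays within the scatter; the furthest is compound 1, whose higher number lies beyond the scatter, so compound 3 is clearly the lower of those two.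

The next step goes from compound 3 to compound 4 `CCC(/C=C1\OC(=O)NC1=O)(CC)c1ccc(-c2ccc3cccc(C(F)(F)F)c3c2)[nH]c1=O`. The structural change is trifluoromethyl in place of ethyl on an aromatic carbon.

Among the compounds with values here, only one measured step touches the same aromatic carbon, namely a 1.3-fold higher number from compound 2 to compound 3 (0.12 log units; within the scatter), and it was within the scatter. Within the data shown here, no measured pair shows trifluoromethyl in place of ethyl, so the expectation for compound 4 rests on that single uninformative step alone and is wide. The working expectation is that the step from compound 3 to compound 4 stays near nothing, a 1.2-fold higher number from compound 3 to compound 4 (0.07 log units; within the scatter), with the direction undecided. Compound 4 is therefore estimated at 20 nM in this assay, with a range of 8 nM to 50 nM.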

Compound 4, inhibition constant: 230 nM
Estimate against measurement, compound 4: 12-fold (1.06 log units) below; measured number outside the range, above it.
By their numbers in this assay, from the lowest: compounds 2 and 3 (each within the scatter of the next); then compound 1; then compound 4.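

In this assay, within the data shown here, the aromatic carbon that looked indifferent in the one earlier comparison, a 1.3-fold higher number from compound 2 to compound 3 (0.12 log units; within the scatter), now proves sensitive to the group it carries: trifluoromethyl in place of ethyl gives a 14-fold higher number from compound 3 to compound 4 (1.13 log units; beyond the scatter) and trifluoromethyl in place of fluoro gives an 18-fold higher number from compound 2 to compound 4 (1.25 log units; beyond the scatter), both large and both beyond the scatter. The earlier step therefore showed only that fluoro and ethyl are interchangeable here within the scatter, and it cannot be extended to every group at this carbon, since the heavier trifluoromethyl stands well apart from both. No measurement bearing on why this one group behaves so differently accompanies these compounds.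

The compounds shown leave open where the tolerance at this carbon ends, which chloro, methoxy, nitrile or a longer chain such as propyl at the same place would help to define. They also leave open whether trifluoromethyl at this carbon carries a similar penalty on the core of compound 1, whose other substituent differs from that of compound 2 and compound 3.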